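A few compounds are considered here, and "the series" means these few. Any claim that something is new, unique, unknown or untested is made for them only; others in the source may bear on it.

In an assay on isolated protein for inhibition of Indoleamine 2,3-dioxygenase 1 (Homo sapiens), read by spectrophotometry (on this read-out lower numbers stand for stronger inhibition and higher numbers for weaker inhibition), compound 1 `O/N=C(/Nc1cccc(Cl)c1)c1ccc2occc2c1` gives 690 nM. For the measured compounds named here, compound 2 `OCc1cc2cc(/C(=N\O)Nc3cccc(Cl)c3)ccc2o1` gives 8000 nM in this assay, and the only measured step, a 12-fold higher number from compound 1 to compound 2 (1.06 log units; beyond the scatter), weakens inhibition clearly. Compound 3 `O/N=C(/Nc1cccc(F)c1)c1ccc2oc(COCC3CC3)cc2c1` gives 2200 nM, the second highest of the three numbers, standing above compound 1 and below compound 2. Compound 4 `O/N=C(/Nc1cccc(Cl)c1)c1ccc2oc(COCC3CC3)cc2c1` differs from compound 3 by chloro in place of fluoro on an aromatic carbon. Going by the values given here, no measured step tracks this exchange; the one known step concerns another position. Compound 1 also carries chloro, but its side chain differs too, so its number cannot isolate the halogen swap. A change no larger than the scatter is therefore expected, and compound 4 is estimated at 1800 nM, within 800 nM to 4000 nM. The expected step is a 1.2-fold lower number from compound 3 to compound 4 (0.09 log units; within the scatter).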

Compound 4, half-maximal inhibitory concentration: 1500 nM
Beside the measured number, compound 4's estimate is 1.2-fold (0.08 log units) above it, and the stated range covers the measured number.
By their numbers in this assay, from the lowest: compound 1; then compounds 4 and 3 (each within the scatter of the next); then compound 2.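

Chloro in place of fluoro on this aromatic carbon gives a shift that stays inside the usual scatter (a 1.5-fold lower number from compound 3 to compound 4 (0.17 log units; within the scatter)), so the exchange shows no real effect here. With chloro in both compounds, cyclopropylmethyl on the oxygen of the hydroxymethyl side chain strengthens inhibition (a 5.3-fold lower number from compound 2 to compound 4 (0.73 log units; beyond the scatter)), yet the whole (cyclopropylmethoxy)methyl group remains weaker than plain hydrogen (a 2.2-fold higher number from compound 1 to compound 4 (0.34 log units; beyond the scatter)). No measurement here offers a reason for these steps. From the compounds shown here alone, whether bromo or methyl on this ring carbon, or an amine on the side chain, would change the number remains open.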